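Swapping a Phenyl Group for a Dioxolane Ring

The compounds below may be only part of what the source reports. "The series", "measured", "known", "first", "only" and "open" are said of these compounds alone.

Of the compounds shown here, three have been tested in a functional assay on B16 cells (Mus musculus) for cytotoxicity, read by MTT assay, with a stated time of 48 h; on this read-out lower numbers stand for stronger inhibition and higher numbers for weaker inhibition. Compound 1 `O=[N+]([O-])c1ccc(-c2cn(Cc3ccccc3)nn2)cc1` gives 5120 nM, the lowest number of the three. Compound 2 `OC(c1ccc2ccccc2c1)c1cn(Cc2ccccc2)nn1` gives 28800 nM, and compound 3 `CC1(C)OCC(Cn2cc(C(O)c3ccc4ccccc4c3)nn2)O1` gives 26900 nM. The cores of compound 1 and compound 2 are not the same, and the difference between them is not broken down here.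

Compound 2 and compound 3 differ in one place only: 2,2-dimethyl-1,3-dioxolan-4-yl in place of phenyl on a saturated chain carbon bound to an aromatic nitrogen. That change produced a 1.1-fold lower number from compound 2 to compound 3 (0.03 log units; within the scatter) in this assay, so the two numbers cannot be told apart.

Compound 4 `CC1(C)OCC(Cn2cc(-c3ccc([N+](=O)[O-])cc3)nn2)O1` has not yet been measured. It stands to compound 1 as compound 3 stands to compound 2, since (2,2-dimethyl-1,3-dioxolan-4-yl in place of phenyl on a saturated chain carbon bound to an aromatic nitrogen). For the measured compounds named here, the same kind of change, made on the same kind of position, left the number essentially unchanged before, and this is the only evidence available. On that basis compound 4 is expected to sit near compound 1, with an estimated step of a 1.0-fold lower number from compound 1 to compound 4 (0.01 log units; within the scatter) in this assay. The estimate for compound 4 is 5000 nM, likely between 2200 nM and 11000 nM.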

Compound 4, half-maximal inhibitory concentration: > 100000 nM
Compound 4 ended at the assay's limit; the forecaster's own chance of this, stated with the estimate: 5%; at least 20-fold (1.30 log units) between middle value and limit.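

In this assay compound 4 gives > 100000 nM, which is a limit of the assay and not an exact number. Putting 2,2-dimethyl-1,3-dioxolan-4-yl in place of phenyl gave an at least 19-fold higher number from compound 1 to compound 4 (1.29 log units; beyond the scatter), so on these two cores the change did not carry over, and its result on one core did not predict its result on the other: the same change on two cores in this assay, a 1.1-fold lower number (0.03 log units; within the scatter) from compound 2 to compound 3 and an at least 19-fold higher number (1.29 log units; beyond the scatter) from compound 1 to compound 4, at least 20-fold (1.32 log units) apart, beyond the scatter of two such steps This shows that the effect of the swap depends on the core it is made on, but it does not show which feature of the cores is responsible, how large the true step is, or how the swap would behave on any third core.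

The compounds shown leave open whether the loss on the core of compound 1 follows from the dioxolane ring specifically or from removing phenyl at this place. An open hexyl chain or a chain ending in an amine, placed on that same core, would help separate these two possibilities.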